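A few compounds are considered here, and "the series" means these few. Any claim that something is new, unique, unknown or untested is made for them only; others in the source may bear on it.

Series notes: compound 3 `COc1cccc(-c2nc(N)c3nc(-c4ccco4)sc3n2)c1` is one of three members measured in an assay on CHO cells for displacement of a labelled ligand from adenosine receptor A1 (Homo sapiens), read by scintillation counting, with a stated time of 3 h; a lower number here means a stronger inhibitor, a higher number a weaker inhibitor. Compound 1 `Nc1nc(-c2cccc(O)c2)nc2sc(-c3ccccc3)nc12` gives 58.5 nM, compound 2 `Nc1nc(-c2cccc(CO)c2)nc2sc(-c3ccco3)nc12` gives 28 nM, and compound 3 gives 62.3 nM. Compound 3 thus carries the highest number of the three; against compound 1 the gap lies within the scatter, against compound 2 it lies beyond it, as the step of a 2.2-fold higher number from compound 2 to compound 3 (0.35 log units; beyond the scatter) shows. Compound 4 `Nc1nc(-c2cccc(O)c2)nc2sc(-c3ccco3)nc12` is not yet measured and differs from compound 3 by hydrogen in place of methyl on an oxygen on an aromatic ring. Among the measured compounds shown here, no measured step covers exactly this change; the only related step is the one from compound 2 to compound 3, of modest size, and compound 1 shows that a hydroxy group on this position is compatible with a similar number. Compound 4 is therefore expected to give 45 nM in this assay, within 20 nM to 110 nM, an expected step of a 1.4-fold lower number from compound 3 to compound 4 (0.14 log units; within the scatter).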

Compound 4, inhibition constant: 51 nM
Compound 4: the middle estimate sits 1.1-fold (0.05 log units) below what was measured, and the stated range covers the measured number.
By their numbers in this assay, from the lowest: compounds 2, 4, 1 and 3 (each within the scatter of the next, the first and the last beyond it).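

In this assay, hydrogen in place of methyl on this oxygen leaves the two compounds within the scatter (a 1.2-fold lower number from compound 3 to compound 4 (0.09 log units; within the scatter)). Hydroxy in place of hydroxymethyl also stays within the scatter (a 1.8-fold higher number from compound 2 to compound 4 (0.26 log units; within the scatter)), although methoxy in place of hydroxymethyl lay beyond it, and furan-2-yl in place of phenyl on the other side of the pair shows the same (a 1.1-fold lower number from compound 1 to compound 4 (0.06 log units; within the scatter)). No data on the cause of these values accompany the series.

Going by these compounds, what an amine or a carboxylic acid in place of the hydroxy would give remains open. So does the effect of a longer chain, such as ethyl, on this oxygen.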